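Adding a chloro group to a weak porcupine inhibitor

The source may hold more compounds than are shown below. What is called first, only, known or untested is meant among the compounds shown, and "the series" means these compounds.

For the measured compounds named here, compound 1 `COc1ccc(-n2nc(C(=O)NCC(=O)Nc3nc4ccccc4s3)c3ccccc3c2=O)cc1` is the only compound here with a measured number: in an assay on L cells for inhibition of Protein-serine O-palmitoleoyltransferase porcupine (Mus musculus), read by reporter gene assay, with a stated time of 24 h (a higher number here means that more compound is needed for the effect, a lower number that less compound is needed), compound 1 gives 25000 nM. Compound 2 `O=C(CNC(=O)c1nn(-c2ccc(F)cc2)c(=O)c2ccccc12)Nc1nc2ccccc2s1` carries a fluoro in place of a methoxy on an aromatic carbon, and in this assay compound 2 reaches only a limit of the assay, > 25000 nM. The step of a number no lower from compound 1 to compound 2 (the limit leaves the size open) therefore has no readable size, and it touches a different ring from the change followed here (the limit of > 25000 nM in this assay, at which 1 of the 2 values shown sits). Compound 3 `COc1ccc(-n2nc(C(=O)NCC(=O)Nc3nc4ccc(Cl)cc4s3)c3ccccc3c2=O)cc1` differs from compound 1 by chloro in place of hydrogen on an aromatic carbon, a chloro in place of hydrogen on an aromatic carbon. Going by the values given here, no measured step covers this position, so there is no ground to expect a step beyond the scatter in either direction. The expected step of no change at the digits printed from compound 1 to compound 3 (within the scatter) is accordingly about none. Compound 3 is estimated at 25000 nM, within 6000 nM to 60000 nM in this assay, with a real chance that only a limit is reported.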

Compound 3, half-maximal effective concentration: 15 nM
For compound 3 the middle estimate is 1700-fold (3.22 log units) above the measured one; measured number outside the range, below it.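

In this assay, the 6-chloro-1,3-benzothiazol-2-yl group in place of 1,3-benzothiazol-2-yl gives a 1700-fold lower number from compound 1 to compound 3 (3.22 log units; beyond the scatter). For the compounds shown here, this position, which no earlier step had touched, therefore responds strongly to substitution: a single chlorine atom separates a compound that needs a great deal of material for the effect from one that needs very little. Nothing shown here explains why this one atom matters so much.

As far as these compounds go, it remains open whether chloro itself is needed at this place, or whether fluoro, methyl, methoxy or an amine would give a similar drop in the number. Also open, from the compounds shown here alone, is whether the same chloro would lower the number for compound 2, which carries fluoro in place of methoxy and whose reading is only a limit of the assay.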